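From phenethyl to a pyridinyl alkyne at the weak end

A few compounds are considered here, and "the series" means these few. Any claim that something is new, unique, unknown or untested is made for them only; others in the source may bear on it.

Compound 1 `CCCCCc1ccc(C#Cc2cn([C@@H]3O[C@H](CO)[C@@H](O)[C@H](O)[C@H]3O)c(=O)nc2N)cc1` gives 132000 nM
Compound 2 `CC(C)(C)c1ccc(C#Cc2cn([C@@H]3O[C@H](CO)[C@@H](O)[C@H](O)[C@H]3O)c(=O)nc2N)cc1` gives > 250000 nM as a limit of the assay, not a number
Compound 3 `O=c1[nH]c(=O)n([C@@H]2O[C@H](CO)[C@@H](O)[C@H](O)[C@H]2O)cc1CCc1ccccc1` gives 300000 nM

In a functional assay on L1210 cells (Mus musculus) for cytotoxicity, with a stated time of 48 h (on this read-out lower numbers stand for stronger inhibition and higher numbers for weaker inhibition), compound 3 holds the higher of the two numbers, and compound 1 lies lower by a gap beyond the scatter. The change to compound 4 (`O=c1[nH]c(=O)n([C@@H]2O[C@H](CO)[C@@H](O)[C@H](O)[C@H]2O)cc1C#Cc1cccnc1`) is 2-(pyridin-3-yl)ethynyl in place of phenethyl on an aromatic carbon. Within the data shown here, the only measured step (an at least 1.8-fold higher number from compound 1 to compound 2 (0.27 log units; that floor lies within the scatter)) is tert-butyl in place of pentyl, so it does not cover this change. In this assay compound 3 stands at 300000 nM. No step beyond the scatter is therefore expected from compound 3, and a reported limit remains possible. The estimated step is a 1.4-fold lower number from compound 3 to compound 4 (0.13 log units; within the scatter) and stays small. For compound 4 the estimate is 220000 nM with an expected range of 90000 nM to 400000 nM in this read-out.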

Compound 4, half-maximal inhibitory concentration: > 250000 nM
Compound 4: no number, only a limit (the forecaster's own chance of this, stated with the estimate: 40%); middle value at least 1.1-fold (0.05 log units) from the limit.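

Among these compounds, compound 4 gives only a limit of the assay, not a number, so no step from compound 3 to compound 4 can be read: the limit of > 250000 nM in this assay, at which 2 of the 4 values shown sit. The compounds shown leave open what 2-(pyridin-3-yl)ethynyl in place of phenethyl does to the read-out.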